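Trimming a sulfonamide substituent in an antiproliferative series

The compounds below may be only part of what the source reports. "The series", "measured", "known", "first", "only" and "open" are said of these compounds alone.

Measured compounds:
Compound 1 `CCC1C(=O)N(C)c2cnc(Nc3ccc(S(=O)(=O)NCC(C)C)cc3)nc2N1c1ccn(C)n1` gives 8520 nM in a functional assay on Huh-7 cells (Homo sapiens) for antiproliferative activity, read by CCK-8 assay, with a stated time of 72 h; on this read-out lower numbers stand for stronger inhibition of growth and higher numbers for weaker inhibition of growth.
Compound 2 `CC[C@@H]1C(=O)N(C)c2cnc(-n3ccc4cc(C(=O)NC(C)C)ccc43)nc2N1C1CCCC1` gives 1660 nM in this assay.
Compound 3 `CC[C@@H]1C(=O)N(C)c2cnc(-n3ccc4cc(C(=O)NC)ccc43)nc2N1C1CCCC1` gives 842 nM in this assay.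

Compound 1 stands at the highest of the three numbers, so it is the weakest inhibitor of growth among them; compound 2 sits well beyond the scatter below it, and compound 3 further still. Compound 4 `CCC1C(=O)N(C)c2cnc(Nc3ccc(S(=O)(=O)NC)cc3)nc2N1c1ccn(C)n1` is not yet measured. It differs from compound 1 in one place: hydrogen in place of isopropyl on a saturated chain carbon bound to a sulfonamide nitrogen. Read one bond further out, the isobutylsulfamoyl group becomes a methylsulfamoyl group.

Going by the values given here, only one measured step resembles this change, the move from compound 2 to compound 3, where a methyl replaces an isopropyl on an amide-type nitrogen: a 2.0-fold lower number from compound 2 to compound 3 (0.29 log units; within the scatter). That step stayed within the scatter, on a different core and at an amide rather than a sulfonamide nitrogen, so it is an indirect guide. Nothing in the data suggests that shortening the group on the sulfonamide nitrogen should produce a large shift in either direction.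

Compound 4 is therefore expected to land close to compound 1, with a step of a 1.3-fold lower number from compound 1 to compound 4 (0.12 log units; within the scatter) that may well fall within the scatter. The estimate for compound 4 is 6500 nM, between 2500 nM and 17000 nM.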

Compound 4, concentration for 50% growth inhibition: 11900 nM
Compound 4: middle estimate off by 1.8-fold (0.26 log units), on the low side, and the stated range covers the measured number.
By their numbers in this assay, from the lowest: compounds 3 and 2 (each within the scatter of the next); then compounds 1 and 4 (each within the scatter of the next).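

In this assay, going by these compounds alone, the step of a 1.4-fold higher number from compound 1 to compound 4 (0.15 log units; within the scatter) gives the first direct reading at this sulfonamide nitrogen, where the isobutylsulfamoyl group becomes a methylsulfamoyl group. On the core of compound 1, then, removing the isopropyl from the saturated chain carbon produces no difference that this assay can resolve, whereas the earlier methyl-for-isopropyl step, on an amide-type nitrogen and a different core, could offer only an indirect hint. No supporting measurement accompanies this result, so the reason for it remains unknown.

The compounds shown leave open whether any group on this sulfonamide nitrogen can move the number beyond the scatter, such as a longer chain like n-hexyl, a cyclopropyl ring, a chain ending in an amine or a carboxylic acid, or simply hydrogen on the nitrogen itself. They also leave open whether the same swap would stay within the scatter on a different core, since this single pair tests it on only one.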